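A few compounds are considered here, and "the series" means these few. Any claim that something is new, unique, unknown or untested is made for them only; others in the source may bear on it.

In a functional assay on HepG2 cells (Homo sapiens) for inhibition, read by MTT assay, with a stated time of 72 h (a lower number here means a stronger inhibitor, a higher number a weaker inhibitor), compound 1 `O=C(Nc1cccc(Br)c1)C1CCN(C/C=C/c2ccccc2)CC1` gives 19200 nM and compound 2 `N#Cc1ccc(NC(=O)C2CCN(C/C=C/c3ccccc3)CC2)cc1` gives 38300 nM. These two numbers lie within the usual scatter of each other, so compound 2 stands level with compound 1 and neither can be ranked. Compound 3 `O=C(Nc1nccs1)C1CCN(C/C=C/c2ccccc2)CC1` keeps the shared core and has 1,3-thiazol-2-yl in place of 4-cyanophenyl on an amide-type nitrogen. Going by the values given here, only one measured step bears on this change, an exchange of groups on that same nitrogen, and it amounts to a 2.0-fold higher number from compound 1 to compound 2 (0.30 log units; within the scatter). Among the compounds with values here, that single step is thin evidence, and no measured compound here carries a five-membered ring at this place. Even so, no shift beyond the scatter is expected in this assay, and no firm direction can be called. The expected change is a 1.3-fold lower number from compound 2 to compound 3 (0.11 log units; within the scatter). For compound 3 the estimate is 30000 nM, with an expected range from 12000 nM to 75000 nM.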

Compound 3, half-maximal inhibitory concentration: 22400 nM
Beside the measured number, compound 3's estimate is 1.3-fold (0.13 log units) above it; the range from low to high includes it.
By their numbers in this assay, from the lowest: compounds 1, 3 and 2 (each within the scatter of the next).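

Replacing the 4-cyanophenyl on the amide-type nitrogen with 1,3-thiazol-2-yl, a five-membered aromatic ring with 2 hetero atoms, gives a 1.7-fold lower number from compound 2 to compound 3 (0.23 log units; within the scatter) in this assay, and replacing the 3-bromophenyl with the same group gives a 1.2-fold higher number from compound 1 to compound 3 (0.07 log units; within the scatter) as well. This place has now taken a five-membered ring as well as two substituted six-membered rings, and all three compounds remain level with one another. Nothing measured here accounts for this lack of separation.

As far as these compounds go, all three compounds carry an aromatic ring on this nitrogen, so it remains open how a non-aromatic group, such as a simple alkyl chain, an aminoethyl chain or a carboxylic acid on a short chain, would read here. From the compounds shown here alone, it is also open whether any group at this place can move the number beyond the scatter.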